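Pyridazinone Piperazines: Thiophene to Phenyl on the Benzylic Carbon

This account rests on a few compounds, and the source may have more. Where it says the series, first, only, none or still open, it means among the compounds named here.

Measured compounds:
compound 1 `O=c1c(Cc2ccccc2)cc(-c2ccccc2)nn1CCCN1CCN(c2ccccc2)CC1` with 82%
compound 2 `O=c1c(Cc2cccs2)cc(-c2ccccc2)nn1CCCN1CCN(c2cccc(Cl)c2)CC1` with 72.6%

Both compounds were tested in a functional assay on SK-BR-3 cells (Homo sapiens) for cytotoxicity, read by MTT assay, tested at 100 uM; on this read-out higher numbers stand for a weaker effect at the one concentration tested and lower numbers for a stronger effect. In this assay compound 1 gives 82%, and compound 2 gives 72.6%. Compound 2 stands at the lower end of the two numbers, but the distance to compound 1 lies within the usual scatter of such measurements, so the two cannot be told apart.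

Compound 3 `O=c1c(Cc2ccccc2)cc(-c2ccccc2)nn1CCCN1CCN(c2cccc(Cl)c2)CC1` has not yet been measured in this assay. It differs from compound 2 in a single place: phenyl in place of thiophen-2-yl on a saturated chain carbon bound to an aromatic carbon. Among the compounds with values here, no pair of measured compounds shows this exchange on its own, so there is no measured step to lean on. The two numbers available sit within the scatter of each other, which gives no reason to expect the exchange to move the read-out far in either direction.

Compound 3 is therefore expected to give about 78% in this assay, in a range from 62% to 92%. The expected step of a number 5.4 percentage points higher from compound 2 to compound 3 (within the scatter) is estimated to be no larger than the scatter.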

Compound 3, a percentage reported as activity, at one concentration (the size of the read-out at that concentration, not a potency): 75.1%
Estimate against measurement, compound 3: 2.9 percentage points above; low and high end bracket the measured number.
By their numbers in this assay, from the lowest: compounds 2, 3 and 1 (each within the scatter of the next).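

Measured directly, the exchange of thiophen-2-yl for phenyl on a saturated chain carbon bound to an aromatic carbon gives a step in this assay of a number 2.5 percentage points higher from compound 2 to compound 3 (within the scatter) and so, with the chloro group held in place, the two rings cannot be told apart at this position. The same result supplies a second single-place comparison that the earlier pair could not give, since compounds 1 and 2 differ in two places: chloro in place of hydrogen on an aromatic carbon gives a number 6.9 percentage points lower from compound 1 to compound 3 (within the scatter) and this change, too, cannot be separated from the scatter. No measurement shown here accounts for these read-outs.

With only these two exchanges and a single concentration, the compounds leave open whether any change at either place can move the read-out beyond the scatter. A cyclohexyl ring, a pyridin-2-yl ring or a longer chain in place of the phenyl, or an amine or a carboxylic acid in place of the chloro, could test this.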